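The compounds below may be only part of what the source reports. "The series", "measured", "known", "first", "only" and "open" are said of these compounds alone.

Measured compounds:
- Compound 1, `FC(F)(F)c1ccccc1-c1nc(NCc2ccccc2)c2ccccc2n1`: 3100 nM
- Compound 2, `COc1ccc(CNc2nc(-c3ccccc3C(F)(F)F)nc3ccccc23)cc1`: 6200 nM
- Compound 3, `FC(F)(F)c1ccccc1-c1nc(NCc2ccc(-c3cncnc3)cc2)c2ccccc2n1`: 3000 nM

All three share one core and differ only in the group on the outer benzene ring. In an assay on a protein complex for inhibition of ubiquitin carboxyl-terminal hydrolase 1/WD repeat-containing protein 48 (Homo sapiens), read by fluorescence (on this read-out higher numbers stand for weaker inhibition and lower numbers for stronger inhibition), compound 2 gives the highest number of the three, so it sits at the weaker end; one neighbouring step is a 2.0-fold higher number from compound 1 to compound 2 (0.30 log units; within the scatter), whereas the gap to compound 3 is a 2.1-fold lower number from compound 2 to compound 3 (0.32 log units; beyond the scatter).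

Compound 4, `FC(F)(F)c1ccccc1-c1nc(NCc2ccc(C3CCCCC3)cc2)c2ccccc2n1`, has not been measured. It differs from compound 2 by cyclohexyl in place of methoxy on an aromatic carbon.

Going by the values given here, the step that bears most directly on this is the one from compound 2 to compound 3, where a ring also took the place of the methoxy and the number fell by a 2.1-fold lower number from compound 2 to compound 3 (0.32 log units; beyond the scatter). The step from compound 1 to compound 3, a 1.0-fold lower number from compound 1 to compound 3 (0.01 log units; within the scatter), shows that a ring at this position leaves the number close to that of the unsubstituted parent. On that basis a small drop from compound 2 is expected for compound 4, roughly a 1.8-fold lower number from compound 2 to compound 4 (0.25 log units; within the scatter), and the expected value for compound 4 is 3500 nM, within 1500 nM to 8000 nM.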

Compound 4, half-maximal inhibitory concentration: 9800 nM
Compound 4: middle estimate off by 2.8-fold (0.45 log units), on the low side; measured number above the stated range.
By their numbers in this assay, from the lowest: compounds 3, 1, 2 and 4 (each within the scatter of the next, the first and the last beyond it).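

In this assay, a ring at this position does not always leave the number close to that of the unsubstituted compound 1, as pyrimidin-5-yl did: cyclohexyl in place of hydrogen gives a clear rise (a 3.2-fold higher number from compound 1 to compound 4 (0.50 log units; beyond the scatter)). The two rings also differ from each other, since the non-aromatic carbon ring gives a higher number than pyrimidin-5-yl (a 3.3-fold higher number from compound 3 to compound 4 (0.51 log units; beyond the scatter)). Against methoxy, however, cyclohexyl cannot be told apart (a 1.6-fold higher number from compound 2 to compound 4 (0.20 log units; within the scatter)), and no measurement here explains the rise.

The compounds shown leave open whether this rise follows from the ring being non-aromatic or from its six carbons. A phenyl ring or a smaller cyclopropyl ring at the same place would help separate those two readings, and a morpholine ring would extend the comparison to a non-aromatic ring that is not all carbon.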